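A few compounds are considered here, and "the series" means these few. Any claim that something is new, unique, unknown or untested is made for them only; others in the source may bear on it.

Measured in a functional assay on HepG2 cells (Homo sapiens) for cytotoxicity, read by MTT assay, with a stated time of 48 h; on this read-out higher numbers stand for weaker inhibition and lower numbers for stronger inhibition:

- Compound 1 `CC1=NN(C(=O)c2ccc([N+](=O)[O-])cc2)C(c2ccccc2O)C1`: 30100 nM
- Compound 2 `CC1=NN(C(=O)c2ccc(C)cc2)C(c2ccccc2O)C1`: 11300 nM
- Compound 3 `CC1=NN(C(=O)c2ccc(C)cc2)C(c2cc(Br)ccc2O)C1`: 23200 nM

Compound 2 has the lowest number of the three, and both other compounds lie beyond the scatter from it. Compound 4 `CCN(CC)CC(=O)N1N=C(C)CC1c1ccccc1O`, not yet measured, differs from compound 2 by a larger change: (diethylamino)methyl in place of 4-methylphenyl on a carbonyl carbon. Put simply, this is (diethylamino)methyl in place of 4-methylphenyl on a carbonyl carbon, so a whole aromatic ring leaves.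

Two measured steps offer only indirect guidance. The first is a 2.7-fold lower number from compound 1 to compound 2 (0.43 log units; beyond the scatter), with methyl in place of nitro on an aromatic carbon. The second is a 2.1-fold higher number from compound 2 to compound 3 (0.31 log units; beyond the scatter), with bromo in place of hydrogen on an aromatic carbon. Both are modest, and neither removes a whole group of this size, so the direction of the new step cannot be read directly from the data. Within the data shown here, compound 2 is the low point so far, and the one step away from it, a 2.1-fold higher number from compound 2 to compound 3 (0.31 log units; beyond the scatter), went upward. A modest rise in this assay is therefore the more likely outcome, with wide uncertainty. The expected change is a 1.9-fold higher number from compound 2 to compound 4 (0.29 log units; within the scatter). For compound 4 the estimated value is 22000 nM, with an expected range from 7000 nM to 70000 nM.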

Compound 4, half-maximal inhibitory concentration: 51600 nM
The estimate for compound 4 lay 2.3-fold (0.37 log units) below the measured number, within the range that was stated.
By their numbers in this assay, from the lowest: compound 2; then compounds 3, 1 and 4 (each within the scatter of the next, the first and the last beyond it).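

In this assay, exchanging 4-methylphenyl for (diethylamino)methyl on the carbonyl carbon gives a 4.6-fold higher number from compound 2 to compound 4 (0.66 log units; beyond the scatter). The earlier steps shown here altered only small groups on aromatic carbons, whereas this one replaces the whole group on the carbonyl carbon, and compound 4 still gives a measurable number, 51600 nM, without that aromatic ring. The change has two parts, since a ring leaves and a nitrogen-bearing chain enters, so this single step cannot separate their contributions, and no measurement shown explains the rise.

A cyclohexyl group on the same carbonyl carbon would keep a ring without adding nitrogen, while a dimethylaminomethyl group or a piperidine ring would keep the amine in a different form, and the compounds shown do not reveal where any of these would fall relative to compound 2 and compound 4. Going by these compounds, it also remains open whether a bromo group on the hydroxyphenyl ring, which accompanied a higher number in compound 3, would shift the number in the same direction when paired with the (diethylamino)methyl group.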